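A few compounds are considered here, and "the series" means these few. Any claim that something is new, unique, unknown or untested is made for them only; others in the source may bear on it.

Measured compounds:
compound 1, `COC(=O)c1cc(=O)c2c(OC)cc(OC)cc2[nH]1`, 16100 nM
compound 2, `COC(=O)c1cc(=O)c2c(OC)cc(OC)cc2n1S(=O)(=O)c1ccc(C)cc1`, 9700 nM
compound 3, `COc1ccc(-c2cc(=O)c3c(OC)cc(OC)cc3n2S(=O)(=O)c2ccc(C=O)cc2)cc1`, > 34400 nM

In a functional assay on SUP-B15 cells (Homo sapiens) for antiproliferative activity, with a stated time of 72 h (a lower number here means that less compound is needed, a higher number that more compound is needed for the effect), compound 1 gives 16100 nM and compound 2 gives 9700 nM. For compound 3 the assay reports only a limit, > 34400 nM, so no number is known for it. Its standing is described by the limit of > 34400 nM in this assay, at which 1 of the 3 values shown sits, and nothing more can be said of where it lies.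

Compound 4, `COc1ccc(-c2cc(=O)c3c(OC)cc(OC)cc3n2S(=O)(=O)c2ccc(Cl)cc2)cc1`, differs from compound 3 by chloro in place of formyl on an aromatic carbon. Going by the values given here, no measured step links a formyl to a chloro on this position, so the expectation rests on the change alone. The step from compound 3 to compound 4 is expected to be a step that the limit leaves unreadable from compound 3 to compound 4, that is, none beyond the scatter. Compound 4 is therefore estimated at 40000 nM in this assay, within 15000 nM to 100000 nM, with a real chance that again only a limit is reported.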

Compound 4, half-maximal effective concentration: > 34400 nM
Compound 4 ended at the assay's limit; the forecaster's own chance of this, stated with the estimate: 60%; the middle value lies beyond the limit too.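

No step from compound 3 to compound 4 can be read in this assay, because both give only a limit and not a number: the limit of > 34400 nM in this assay, at which 2 of the 4 values shown sit.

As far as these compounds go, whether chloro and formyl differ at all on this aromatic carbon stays open.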